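This account rests on a few compounds, and the source may have more. Where it says the series, first, only, none or still open, it means among the compounds named here.

Compound 3 `C#CCNC1c2cccc(OC)c2OCC1(C)C` was examined in an assay on BTI cells for inhibition of Amine oxidase [flavin-containing] A (Homo sapiens), read by fluorescence, with a stated time of 20 min, tested at 1 uM (a higher number here means more inhibition at the concentration tested (going by the name of the read-out), a lower number less inhibition), where compound 3 gives 4.6%. Among the three measured compounds this is the second highest number: the nearest is compound 1 `COc1cccc2c1OCC(C)(C)C2N`, which in this assay gives -0.7%, a number lower but within the scatter, and the furthest is compound 2 `COc1cccc2c1C(=O)C(C)(C)CO2`, which gives 12.1%, higher yet still within the scatter. Compound 4 `C#CCN(Cc1ccccc1)C1c2cccc(OC)c2OCC1(C)C` differs from compound 3 by benzyl in place of hydrogen on an amine nitrogen. Within the data shown here, the only measured step on an amine nitrogen, a number 5.3 percentage points higher from compound 1 to compound 3 (within the scatter), stayed within the scatter, and no measured step involves a benzyl group. Compound 4 is therefore expected to shift by a number 3.4 percentage points higher from compound 3 to compound 4 (within the scatter), that is, no step beyond the scatter. The estimate for compound 4 in this assay is 8%, expected to fall between -10% and 26%.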

Compound 4, a percentage reported as inhibition, at one concentration (the size of the read-out at that concentration, not a potency): 4.3%
Compound 4: the middle estimate sits 3.7 percentage points above what was measured, and the stated range covers the measured number.
By their numbers in this assay, from the lowest: compounds 1, 4, 3 and 2 (each within the scatter of the next, the first and the last beyond it).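

In this assay, benzyl in place of hydrogen on the amine nitrogen gave a number 0.3 percentage points lower from compound 3 to compound 4 (within the scatter). This is the first step shown to add a second group to a nitrogen already carrying propargyl, and a group with an aromatic ring on this nitrogen gave no step beyond the scatter. No further measurement bears on this result. Still open, going by these compounds, is whether a methyl or a longer chain on this nitrogen, or a carboxylic acid on the benzyl ring, would give a step beyond the scatter.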